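Vinyl to but-3-en-1-yl in the diyne series

This account rests on a few compounds, and the source may have more. Where it says the series, first, only, none or still open, it means among the compounds named here.

Two diynes have been run in a functional assay on XF498 cells (Homo sapiens) for cytotoxicity; a lower number here means that less compound is needed, a higher number that more compound is needed for the effect. Compound 1 `C=CCCCCCC#CC#CCO` gives 10.8 ug/mL, and compound 2 `C=CCCCCCC#CC#CC(O)CC(C)=O` gives 3.87 ug/mL. Within the data shown here, the single measured step, a 2.8-fold lower number from compound 1 to compound 2 (0.45 log units; beyond the scatter), sits at a saturated chain carbon bound to an oxygen and does not involve the vinyl group. Among the measured compounds shown here, on the numbers so far compound 2 stands lowest of the two, with compound 1 as its nearest neighbour at a higher value.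

Compound 3 `C=CCCCCCCCC#CC#CC(O)CC(C)=O` differs from compound 2 by but-3-en-1-yl in place of vinyl on a saturated chain carbon, five bonds along the chain from a triple-bonded carbon. For the measured compounds named here, no measured step touches this part of the molecule, so the one step available gives no guide to either size or direction here. Going by the values given here, with no precedent for lengthening the alkenyl chain, the expected step is a 1.0-fold higher number from compound 2 to compound 3 (0.01 log units; within the scatter), none beyond the scatter. Compound 3 is therefore estimated at 4 ug/mL. The expected range for compound 3 runs from 1.8 ug/mL to 9 ug/mL.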

Compound 3, concentration for half-maximal effect: 4.45 ug/mL
Estimate against measurement, compound 3: 1.1-fold (0.05 log units) below, within the range that was stated.
By their numbers in this assay, from the lowest: compounds 2 and 3 (each within the scatter of the next); then compound 1.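

In this assay, among these compounds, but-3-en-1-yl in place of vinyl on a saturated chain carbon, five bonds along the chain from a triple-bonded carbon, gives a 1.1-fold higher number from compound 2 to compound 3 (0.06 log units; within the scatter) and is the first measured step at this end of the molecule. The position therefore accepts the longer but-3-en-1-yl with its double bond kept, and this read-out does not separate compound 2 from compound 3. No measurement is available to explain this result.

From the compounds shown here alone, whether the tolerance extends to a longer chain such as hex-5-en-1-yl, or to a saturated ethyl or a terminal amine at this end, remains open. Also open, going by these compounds, is whether the 2-oxopropyl step, so far read only on the vinyl-ended chain, carries over to the but-3-en-1-yl chain.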